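A few compounds are considered here, and "the series" means these few. Any claim that something is new, unique, unknown or untested is made for them only; others in the source may bear on it.

Compound 1 `Fc1ccccc1CSc1nnc(-c2ccncc2)n1-c1ccccc1`, compound 2 `Clc1ccccc1CSc1nnc(-c2ccncc2)n1-c1ccccc1`, compound 3 `Fc1ccc(CSc2nnc(-c3ccncc3)n2-c2ccccc2)cc1` and compound 4 `Clc1ccc(CSc2nnc(-c3ccncc3)n2-c2ccccc2)cc1` share one core and differ only in the benzyl group attached to the sulfur. In a functional assay on HepG2 cells (Homo sapiens) for inhibition, read by MTT assay, with a stated time of 48 h (on this read-out lower numbers stand for stronger inhibition and higher numbers for weaker inhibition), compound 1 gives only a limit, > 50000 nM, and no number (the limit of > 50000 nM in this assay, at which 1 of the 3 values shown sits). In this assay compound 2 gives 15700 nM. In this assay compound 3 gives 15600 nM. The change chloro in place of fluoro on an aromatic carbon made a step of an at least 3.1-fold lower number from compound 1 to compound 2 (0.50 log units; beyond the scatter). Compound 1 and compound 3 differ as 4-fluorophenyl in place of 2-fluorophenyl on a saturated chain carbon bound to a sulfur, the same atoms joined differently, and that change made a step of an at least 3.2-fold lower number from compound 1 to compound 3 (0.50 log units; beyond the scatter). Between the two measured numbers the step is a 1.0-fold lower number from compound 2 to compound 3 (0.00 log units; within the scatter). Compound 4 is not yet measured. Among the compounds with values here, its difference from compound 3 is chloro in place of fluoro on an aromatic carbon; this is the same kind of change as the one that produced compound 2, but there the chlorine stands ortho to a large group and here para to a large group. The earlier step started from a limit, so its true size is open. The step from compound 3 to compound 4 in this assay is expected to be modest, a 1.6-fold lower number from compound 3 to compound 4 (0.19 log units; within the scatter). Compound 4 is therefore expected to give about 10000 nM, most likely between 4000 nM and 25000 nM.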

Compound 4, half-maximal inhibitory concentration: 16900 nM
For compound 4 the middle estimate is 1.7-fold (0.23 log units) below the measured one, within the range that was stated.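

The change from fluoro to chloro did not give one fixed step across these two pairs in this assay: the same change on two cores in this assay, an at least 3.1-fold lower number (0.50 log units; beyond the scatter) from compound 1 to compound 2 and a 1.1-fold higher number (0.03 log units; within the scatter) from compound 3 to compound 4, at least 3.4-fold (0.53 log units) apart, beyond the scatter of two such steps. Within the data shown here, with the halogen para to a large group the step is a 1.1-fold higher number from compound 3 to compound 4 (0.03 log units; within the scatter), so chloro and fluoro cannot be told apart there; compound 4 also shows a 1.1-fold higher number from compound 2 to compound 4 (0.03 log units; within the scatter), while an at least 2.9-fold lower number from compound 1 to compound 4 (0.47 log units; beyond the scatter) is the one step here that lies beyond the scatter. Going by these compounds, compound 1 gives only a limit, so the true size of the earlier step stays open, and two pairs that also differ in where the halogen stands give no general rule for this change: the limit of > 50000 nM in this assay, at which 1 of the 4 values shown sits.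

The compounds shown leave open how a methyl, a methoxy or a nitrile in place of the halogen on the benzyl group would read in this assay. They also leave open what a phenethyl group in place of the benzyl group, or an amine on its phenyl ring, would do to the number.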